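Triazole ester analogues at the edge of an antiproliferative assay

The source may hold more compounds than are shown below. What is called first, only, known or untested is meant among the compounds shown, and "the series" means these compounds.

Three esters of one terpenoid core were tested in a functional assay on DU-145 cells (Homo sapiens) for antiproliferative activity, read by MTT assay, with a stated time of 48 h; a higher number here means a weaker inhibitor, a lower number a stronger inhibitor. Compound 1, `C/C(=C\CC/C(C)=C/CC[C@@H]1[C@@]2(C)CCC(=O)C(C)(C)[C@H]2CC[C@@]1(C)O)CC/C=C(\C)C(=O)OCc1cn(-c2ccc(F)cc2)nn1`, carries a 4-fluorophenyl group on the triazole. In this assay compound 1 reaches only the limit > 150000 nM. Compound 2, `C/C(=C\CC/C(C)=C/CC[C@@H]1[C@@]2(C)CCC(=O)C(C)(C)[C@H]2CC[C@@]1(C)O)CC/C=C(\C)C(=O)OCc1cn(-c2ccc(C(C)(C)C)cc2)nn1`, carries a 4-(tert-butyl)phenyl group instead. In this assay compound 2 likewise reaches only the limit > 150000 nM. Compound 3, `C/C(=C\CC/C(C)=C/CC[C@@H]1[C@@]2(C)CCC(=O)C(C)(C)[C@H]2CC[C@@]1(C)O)CC/C=C(\C)C(=O)OCc1cn(-c2ccccc2F)nn1`, carries a 2-fluorophenyl group. In this assay compound 3 again gives only the limit > 150000 nM. The steps among them are therefore a step that the two limits leave unreadable from compound 1 to compound 2, a step that the two limits leave unreadable from compound 1 to compound 3 and a step that the two limits leave unreadable from compound 2 to compound 3. Compound 3 thus stands at the limit together with the other two, as the limit of > 150000 nM in this assay, at which 3 of the 3 values shown sit, records.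

Compound 4, `COc1ccc(-n2cc(COC(=O)/C(C)=C/CC/C(C)=C/CC/C(C)=C/CC[C@@H]3[C@@]4(C)CCC(=O)C(C)(C)[C@H]4CC[C@@]3(C)O)nn2)cc1`, is reached by the change (4-methoxyphenyl in place of 2-fluorophenyl on an aromatic nitrogen). No measured step of this kind is readable, since every step shown runs between two limits. Nothing among the three measured compounds suggests that any aryl group on the triazole nitrogen moves the read-out off the limit, so the step that the limit leaves unreadable from compound 3 to compound 4 is expected to be one that a further limit leaves unreadable. Compound 4 is accordingly estimated at 200000 nM, with a range from 90000 nM to 600000 nM, most probably reported as a limit rather than as a number.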

Compound 4, half-maximal inhibitory concentration: 135000 nM
Estimate against measurement, compound 4: 1.5-fold (0.17 log units) above; the range from low to high includes it.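

In this assay, within the data shown here, compound 4 gives 135000 nM, the first value that is a number and not a limit, which shows that a group on this triazole nitrogen can bring the read-out within the range of the assay. On these data alone, the 4-methoxyphenyl group in place of 2-fluorophenyl gives an at least 1.1-fold lower number from compound 3 to compound 4 (0.04 log units; that floor lies within the scatter), methoxy in place of tert-butyl gives an at least 1.1-fold lower number from compound 2 to compound 4 (0.04 log units; that floor lies within the scatter), and methoxy in place of fluoro gives an at least 1.1-fold lower number from compound 1 to compound 4 (0.04 log units; that floor lies within the scatter); each of these is only a floor, so the true size of all three steps remains unknown and could be no more than scatter or could be larger. The steps among the other three compounds still cannot be read, and those compounds stay at a limit: the limit of > 150000 nM in this assay, at which 3 of the 4 values shown sit.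

As far as these compounds go, it remains open whether an amine or a hydroxyl group in place of the methoxy, or a longer alkoxy chain, would take the number clearly away from the limit. Also open, from the compounds shown here alone, is whether the shared core would respond the same way if an amide replaced the ester that links it to the triazole.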